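Compound 3 to compound 4: 3-bromophenyl replaces 4-iodophenyl

This account rests on a few compounds, and the source may have more. Where it says the series, first, only, none or still open, it means among the compounds named here.

Three amides sharing one core have been tested in a functional assay on SK-OV-3 cells (Homo sapiens) for antiproliferative activity, read by MTT assay, with a stated time of 72 h; a lower number here means a stronger inhibitor, a higher number a weaker inhibitor. Compound 1 `O=C(CCc1cccc2c1B(O)OC2)NC1CCCCC1`, with cyclohexyl on the amide-type nitrogen, gives > 100000 nM, which is a limit of the assay and not a number. Compound 2 `O=C(CCc1cccc2c1B(O)OC2)Nc1ccc(Cl)cc1` gives 5000 nM. Compound 3 `O=C(CCc1cccc2c1B(O)OC2)Nc1ccc(I)cc1` gives 51000 nM, the higher of the two true numbers.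

Compound 4 `O=C(CCc1cccc2c1B(O)OC2)Nc1cccc(Br)c1` is still unmeasured, and its change is 3-bromophenyl in place of 4-iodophenyl on an amide-type nitrogen. Within the data shown here, no measured compound carries a 3-bromophenyl, so no step matches this change directly. The closest is the large 10-fold higher number from compound 2 to compound 3 (1.01 log units; beyond the scatter), iodo in place of chloro on an aromatic carbon. The large at least 20-fold lower number from compound 1 to compound 2 (1.30 log units; beyond the scatter) and the floor-only an at least 1.9-fold lower number from compound 1 to compound 3 (0.29 log units; that floor lies within the scatter) bear on it less, since both replace cyclohexyl.

Leaving the iodo compound is expected to move the number down, though not all the way to compound 2, because a 10-fold higher number from compound 2 to compound 3 (1.01 log units; beyond the scatter) shows how far a halogen swap can reach. The expected change is a 2.6-fold lower number from compound 3 to compound 4 (0.41 log units; beyond the scatter), a moderate step. For compound 4 the estimate is 20000 nM, with an expected range of 4500 nM to 90000 nM.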

Compound 4, half-maximal inhibitory concentration: 540 nM
Estimate against measurement, compound 4: 37-fold (1.57 log units) above; the whole stated range lies above it.
By their numbers in this assay, from the lowest: compound 4; then compound 2; then compound 3. At a limit, above all of these: compound 1.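

Moving from 4-iodophenyl to 3-bromophenyl on the amide-type nitrogen shifts the number in this assay: a 94-fold lower number from compound 3 to compound 4 (1.98 log units; beyond the scatter). That is a much larger shift than the halogen swap gave, with a 10-fold higher number from compound 2 to compound 3 (1.01 log units; beyond the scatter). Among these compounds, the new aryl group also goes well past the 4-chlorophenyl amide, with a 9.3-fold lower number from compound 2 to compound 4 (0.97 log units; beyond the scatter), so this position can give a far lower number than the earlier compounds showed. Compound 1 stands at a limit of the assay, and an at least 180-fold lower number from compound 1 to compound 4 (2.26 log units; beyond the scatter) is therefore only a floor: the limit of > 100000 nM in this assay, at which 1 of the 4 values shown sits.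

Compound 4 differs from compound 3 in both the halogen and the place it occupies on the ring, and the compounds shown do not separate these two changes. They also leave open how an unsubstituted phenyl or a phenyl bearing a nitrile would read in this assay.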